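The source may hold more compounds than are shown below. What is called first, only, known or untested is meant among the compounds shown, and "the series" means these compounds.

Series on the shared core of compound 1 `CCOC(=O)CCCCCOc1cccc(CN(C(=O)c2ccc(-c3cccc(-c4ccccc4)c3)cc2)C(C)C)c1`, varied at the aryl group attached to the benzamide ring. In an ADME assay on BJ cells (Homo sapiens) for cytotoxicity, read by CellTiter-Glo and resazurin assay, with a stated time of 72 h (on this read-out lower numbers stand for an effect already at smaller amounts and higher numbers for an effect only at larger amounts of compound), compound 1 gives > 26000 nM, which is a limit of the assay and not a number. Compound 2 `CCOC(=O)CCCCCOc1cccc(CN(C(=O)c2ccc(-c3cnc(OC)nc3OC)cc2)C(C)C)c1` carries 2,4-dimethoxypyrimidin-5-yl at that position; in this assay compound 2 gives > 26000 nM, again a limit. Compound 3 `CCOC(=O)CCCCCOc1cccc(CN(C(=O)c2ccc(-c3ccc4cc[nH]c4c3)cc2)C(C)C)c1` carries 1H-indol-6-yl there; in this assay compound 3 gives > 26000 nM, also a limit. The steps a step that the two limits leave unreadable from compound 1 to compound 2, a step that the two limits leave unreadable from compound 1 to compound 3 and a step that the two limits leave unreadable from compound 2 to compound 3 are accordingly of unreadable size, with all three values sitting at the limit of > 26000 nM in this assay, at which 3 of the 3 values shown sit. Compound 3 thus stands at the limit together with the other two, and no order among them can be read.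

Compound 4 `CCOC(=O)CCCCCOc1cccc(CN(C(=O)c2ccc(-c3cc(OC)cc(OC)c3)cc2)C(C)C)c1` differs from compound 3 by 3,5-dimethoxyphenyl in place of 1H-indol-6-yl on an aromatic carbon. Among the compounds with values here, none of the measured aryl swaps yielded a readable step, so no size can be carried over. The step that the limit leaves unreadable from compound 3 to compound 4 is expected to remain within the scatter. Compound 4 is estimated at 30000 nM, with a range from 15000 nM to 100000 nM, most likely reported once more as a limit.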

Compound 4, half-maximal effective concentration: > 26000 nM
Compound 4 gave a limit, no number; the forecaster's own chance of this, stated with the estimate: 85%; the middle value is on the limit's open side.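

In this assay compound 4 gives > 26000 nM, a limit and not a number. The steps from compound 1, compound 2 and compound 3 to compound 4 cannot be read, and the series stays flat at: the limit of > 26000 nM in this assay, at which 4 of the 4 values shown sit.

The compounds shown leave open whether any aryl group at this position gives a readable value, and how these four compounds would rank.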